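The source may report more compounds than this note shows. Statements on the series, on what has been measured and on what is new or still open speak of the compounds shown alone.

Measured compounds in a functional assay on A549 cells (Homo sapiens) for antiproliferative activity, read by MTT assay, with a stated time of 48 h; a lower number here means a stronger inhibitor, a higher number a weaker inhibitor:
compound 1 `Cc1cc(Nc2nc(Nc3ccc(C(=O)NC4CC(C)(C)N([O])C(C)(C)C4)cc3)ncc2[N+](=O)[O-])no1`: 1140 nM
compound 2 `Cc1cc(Nc2nc(Nc3ccc(C(=O)NC4CC(C)(C)N([O])C(C)(C)C4)cc3)ncc2[N+](=O)[O-])n[nH]1`: 15300 nM
compound 3 `Cc1cc(Nc2nc(Nc3ccc(C(=O)NC4CC(C)(C)N([O])C(C)(C)C4)cc3)ncc2F)no1`: 880 nM

Compound 4 `Cc1cc(Nc2nc(Nc3ccc(C(=O)NC4CC(C)(C)N([O])C(C)(C)C4)cc3)ncc2F)n[nH]1` has not yet been measured. It differs from compound 3 by 5-methyl-1H-pyrazol-3-yl in place of 5-methyl-1,2-oxazol-3-yl on a nitrogen on an aromatic ring. The same change has been made once before, from compound 1 to compound 2, where it reads 5-methyl-1H-pyrazol-3-yl in place of 5-methyl-1,2-oxazol-3-yl on a nitrogen on an aromatic ring and gave a 13-fold higher number from compound 1 to compound 2 (1.13 log units; beyond the scatter) in this assay. The two cores differ only by fluoro in place of nitro on an aromatic carbon, a change that gave a 1.3-fold lower number from compound 1 to compound 3 (0.11 log units; within the scatter) in this assay. Since the place of the change is the same word for word in both pairs and the core difference is small, a step of similar size is expected from compound 3 to compound 4, namely a 13-fold higher number from compound 3 to compound 4 (1.10 log units; beyond the scatter), resting on the value of compound 3 and on the earlier step between compound 1 and compound 2. Compound 4 is therefore estimated at 11000 nM in this assay, with a range from 4000 nM to 30000 nM.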

Compound 4, half-maximal inhibitory concentration: 2120 nM
For compound 4 the middle estimate is 5.2-fold (0.72 log units) above the measured one; measured number outside the range, below it.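

In this assay the change to 5-methyl-1H-pyrazol-3-yl raises the number on both cores, but on the fluoro-bearing core it gives only a 2.4-fold higher number from compound 3 to compound 4 (0.38 log units; beyond the scatter), so the direction carries over while the size does not: the same change on two cores in this assay, a 13-fold higher number (1.13 log units; beyond the scatter) from compound 1 to compound 2 and a 2.4-fold higher number (0.38 log units; beyond the scatter) from compound 3 to compound 4, 5.6-fold (0.75 log units) apart, beyond the scatter of two such steps.
Read the other way, fluoro in place of nitro gives a 7.2-fold lower number from compound 2 to compound 4 (0.86 log units; beyond the scatter), so that step too depends on the group on the nitrogen: the same change on two cores in this assay, a 1.3-fold lower number (0.11 log units; within the scatter) from compound 1 to compound 3 and a 7.2-fold lower number (0.86 log units; beyond the scatter) from compound 2 to compound 4, 5.6-fold (0.75 log units) apart, beyond the scatter of two such steps.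
Two pairs do not show what sets the size of the step, or how it would run on any other core.

The compounds shown leave open how a phenyl ring or a longer alkyl chain on that nitrogen would behave. They also leave open whether chloro or a nitrile in place of fluoro would give a similar number.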